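The compounds below may be only part of what the source reports. "The series", "measured", "known", "first", "only" and "open" are said of these compounds alone.

Of the compounds shown here, three share one core and have been tested in an assay on isolated protein for inhibition of protein tyrosine phosphatase type IVA 3 (Homo sapiens), tested at 5 ug/mL; a higher number here means more inhibition at the concentration tested (going by the name of the read-out), a lower number less inhibition. Compound 1 `COc1ccccc1COc1ccccc1/C=C/C=C1\SC(=S)NC1=O` gives 78.8%, compound 2 `COc1cccc(COc2ccccc2/C=C/C=C2\SC(=S)NC2=O)c1` gives 52.9%, and compound 3 `COc1ccccc1/C=C/C=C1\SC(=S)NC1=O` gives 41.7%, the lowest of the three; its nearest neighbour is compound 2, and the gap a number 11.2 percentage points lower from compound 2 to compound 3 (beyond the scatter) lies beyond the scatter, while the larger gap a number 37.1 percentage points lower from compound 1 to compound 3 (beyond the scatter) does too. Between compound 1 and compound 2 the change was a number 25.9 percentage points lower from compound 1 to compound 2 (beyond the scatter).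

Compound 4 `O=C1NC(=S)S/C1=C\C=C\c1ccccc1O` differs from compound 3 by hydrogen in place of methyl on an oxygen on an aromatic ring. For the measured compounds named here, no measured step touches this oxygen directly: every measured step changes the group on the saturated chain carbon bound to that oxygen. Those steps all point the same way, toward lower inhibition as the group there shrinks, with compound 3, the smallest, at the bottom. Removing the remaining methyl continues in that direction, so the expected step in this assay is a modest decrease, a number 11.7 percentage points lower from compound 3 to compound 4 (beyond the scatter), possibly within the scatter. Compound 4 is therefore estimated at 30%, within a range from 10% to 55%.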

Compound 4, a percentage reported as inhibition, at one concentration (the size of the read-out at that concentration, not a potency): 51.9%
Beside the measured number, compound 4's estimate is 21.9 percentage points below it, and the stated range covers the measured number.
By their numbers in this assay, from the lowest: compound 3; then compounds 4 and 2 (each within the scatter of the next); then compound 1.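

Methoxy to hydroxy on this oxygen gives a number 10.2 percentage points higher from compound 3 to compound 4 (beyond the scatter) in this assay, so the smallest group here does not give the lowest number. The earlier trend, in which a smaller group on this oxygen went with lower inhibition across compounds 1, 2 and 3, therefore does not extend to hydrogen, and compound 4 goes against it. Nothing available explains this change of direction.

Open, as far as these compounds go, is what an ethyl group or a longer chain on this oxygen would do, and whether the numbers would rise or fall steadily from hydrogen through such chains to the larger groups. An unsubstituted benzyl group or a 4-methoxyphenyl group on the chain carbon would also show how much of the higher numbers depends on the methoxy group.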